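A few compounds are considered here, and "the series" means these few. Any claim that something is new, unique, unknown or untested is made for them only; others in the source may bear on it.

Measured so far in an in vitro functional assay on cells for agonist activity at Bombesin receptor subtype-3 (Homo sapiens), read by luminescence and calcium flux; a higher number here means that more compound is needed for the effect, a lower number that less compound is needed:
compound 1, `O=C(O)c1ccccc1-c1ccc(CCc2ncc(CC3CCCCC3)[nH]2)cc1`: 41 nM
compound 2, `Cc1ccccc1Cc1cnc(CCc2ccc(-c3ccccc3C(=O)O)cc2)[nH]1`: 127 nM
compound 3, `O=C(O)c1ccccc1-c1ccc(CCc2ncc(CCC3CCCCC3)[nH]2)cc1`: 642 nM

Compound 2 stands second highest of the three numbers, with a 3.1-fold higher number from compound 1 to compound 2 (0.49 log units; beyond the scatter) on one side and a 5.1-fold higher number from compound 2 to compound 3 (0.70 log units; beyond the scatter) on the other; the widest gap in the set is a 16-fold higher number from compound 1 to compound 3 (1.19 log units; beyond the scatter). Compound 4, `CC(C)(C)CCc1cnc(CCc2ccc(-c3ccccc3C(=O)O)cc2)[nH]1`, is not yet measured in this assay. Its change from compound 2: neopentyl in place of 2-methylphenyl on a saturated chain carbon bound to an aromatic carbon. The two measured exchanges at this place both moved the number beyond the scatter, and the one that brought in a group with a saturated carbon between the chain and the bulk raised it. The entering neopentyl has no ring and carries its bulk in the same way, so a modest rise is expected. The step is estimated as a 2.8-fold higher number from compound 2 to compound 4 (0.44 log units; beyond the scatter). Compound 4 is therefore expected near 350 nM, within 110 nM to 1100 nM.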

Compound 4, half-maximal effective concentration: 39 nM
Beside the measured number, compound 4's estimate is 9.0-fold (0.95 log units) above it, and the stated range ends above it.
By their numbers in this assay, from the lowest: compounds 4 and 1 (each within the scatter of the next); then compound 2; then compound 3.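

In this assay, a ring is not required at this place: neopentyl, which has no ring, gives a 3.3-fold lower number from compound 2 to compound 4 (0.51 log units; beyond the scatter) in exchange for 2-methylphenyl, and a 1.1-fold lower number from compound 1 to compound 4 (0.02 log units; within the scatter) in exchange for cyclohexyl. On the same chain, tert-butyl in place of cyclohexyl gives a 16-fold lower number from compound 3 to compound 4 (1.22 log units; beyond the scatter), so chain length alone does not set the high number of compound 3. Nothing measured here explains these steps. Going by these compounds, whether a longer chain ending in tert-butyl, or an amine or hydroxyl on this chain, keeps the number low remains open.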